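A few compounds are considered here, and "the series" means these few. Any claim that something is new, unique, unknown or untested is made for them only; others in the source may bear on it.

This study follows a small set of compounds that share one core and differ only in the group sitting on a saturated ring carbon of a six-membered non-aromatic ring of carbon only. Compound 1 `CC[C@]1(C(=O)O)CC[C@H](C(=O)N2CC[C@](c3ccc(C(F)(C(F)(F)F)C(F)(F)F)cc3)(S(=O)(=O)c3ccc(F)cc3)C2)CC1` carries an ethyl group there, compound 2 `C[C@]1(C(=O)N2CC[C@](c3ccc(C(F)(C(F)(F)F)C(F)(F)F)cc3)(S(=O)(=O)c3ccc(F)cc3)C2)CC[C@H](C(=O)O)CC1` a methyl group, and compound 3 `CCC[C@]1(C(=O)N2CC[C@](c3ccc(C(F)(C(F)(F)F)C(F)(F)F)cc3)(S(=O)(=O)c3ccc(F)cc3)C2)CC[C@H](C(=O)O)CC1` a propyl group. In an ADME assay on microsomes from liver (Mus musculus) for metabolic stability, with a stated time of 10 min (a higher number here means that more of the compound is left, a lower number that less of the compound is left), compound 2 gives 95%, so nearly all of it is left after the stated time. For compound 1 this assay returned "not determined" (no result reported), and for compound 3 it returned "not determined" (no result reported), so compound 3 cannot be placed on the measured scale and the only anchor in the series is compound 2.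

The step from compound 3 to compound 4 `CO[C@]1(C(=O)N2CC[C@](c3ccc(C(F)(C(F)(F)F)C(F)(F)F)cc3)(S(=O)(=O)c3ccc(F)cc3)C2)CC[C@H](C(=O)O)CC1` is a change of the same group: methoxy in place of propyl on a saturated ring carbon. Going by the values given here, no measured pair in this set shows the size of such a step, so there is nothing to read a direction from; the expectation is a step that stays within the scatter of this assay, with the high value of compound 2 as the nearest reference. On that basis compound 4 is expected to give about 85% in this assay, with a likely range from 60% to 99%.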

Compound 4, percent of the compound remaining: 95%
Estimate against measurement, compound 4: 10 percentage points below, within the range that was stated.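

In this assay, compound 4 supplies a second measured point at this saturated ring carbon, and the result reads no change at the digits printed from compound 2 to compound 4 (within the scatter). Going by these compounds alone, this is the first sign that the group on this carbon can be swapped with no readable difference in this read-out: methoxy, which brings an oxygen and a hydrogen-bond acceptor, cannot be told apart from methyl, and in both compounds nearly all of the material is left after the stated time. Within the data shown here, the data offered here give no explanation for this match, and the statement covers only this one pair of compounds.

Steps that touch compound 1 or compound 3 cannot be read, as neither has a number in this assay, so the ethyl and propyl groups say nothing yet about how chain length at this carbon plays out. From the compounds shown here alone, it also remains open whether a longer ether such as ethoxy, a hydroxy group or an amine on the same carbon would stay level with methyl and methoxy or fall away from them.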